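The source may report more compounds than this note shows. Statements on the series, on what has been measured and on what is new or still open speak of the compounds shown alone.

Three compounds have so far been measured in a functional assay on the whole organism (artery, strain albino) with Rattus norvegicus as the target, with a stated time of 720 min, at a dose of 10 mg/kg by the oral route; on this read-out higher numbers stand for more inhibition at the one dose given (going by the name of the read-out) and lower numbers for less inhibition:

Compound 1 `CC1=C(C(=O)Nc2ccc(Br)cc2)C(c2ccc(Cl)cc2Cl)N=C(SCc2ccccc2Cl)N1` gives 20.6%.
Compound 2 `CC1=C(C(=O)Nc2ccc(Br)cc2)C(c2ccc(Cl)cc2Cl)N=C(SCc2cccc(Cl)c2)N1` gives 11.3%.
Compound 3 `CC1=C(C(=O)Nc2ccc([N+](=O)[O-])cc2)C(c2ccc(Br)cc2)N=C(SCc2ccccc2)N1` gives 21.1%.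

Compound 3 holds the highest of these three numbers, yet both compound 1 and compound 2 sit within the usual scatter of it, so the three read as one level rather than an order. Compound 4 `CC1=C(C(=O)Nc2ccc([N+](=O)[O-])cc2)C(c2ccc(Br)cc2)N=C(SCc2ccc(F)cc2)N1` differs from compound 3 by fluoro in place of hydrogen on an aromatic carbon. For the measured compounds named here, only one measured step touches the same part of the shared core, the aromatic ring on the saturated chain carbon bound to a sulfur: a number 9.3 percentage points lower from compound 1 to compound 2 (within the scatter), a step that stayed within the scatter. Going by the values given here, no measured step exchanges a hydrogen for a fluoro anywhere, so there is no direct precedent for the change itself. Taken together, the one step at that ring gives no reason to expect a move beyond the scatter in this assay . Compound 4 is therefore estimated at 21%, with a range from 9% to 33%. The expected step is a number 0.1 percentage points lower from compound 3 to compound 4 (within the scatter), which is no more than the scatter.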

Compound 4, a percentage reported as inhibition, in the whole organism at one dose (the size of the read-out at that dose, not a potency): 27.3%
The estimate for compound 4 lay 6.3 percentage points below the measured number; the measured number falls inside the stated range.
By their numbers in this assay, from the lowest: compounds 2, 1, 3 and 4 (each within the scatter of the next, the first and the last beyond it).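

In this assay, for the compounds shown here, the step from phenyl to 4-fluorophenyl gives a number 6.2 percentage points higher from compound 3 to compound 4 (within the scatter), the first measured exchange of hydrogen for fluoro on this ring. It shows that a fluoro on this aromatic carbon, para to a large group, is accepted without a move beyond the scatter, whereas the earlier step at this ring only shifted a chlorine on an already substituted ring. Nothing measured here bears on why the step has this size.

The compounds shown leave open whether a different group at this place, such as an amine, a methoxy group or a carboxylic acid, would carry the number beyond the scatter. They also leave open whether fluoro at this place would give a similar step on the core of compound 1.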